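From hydroxy to benzyloxy: estimating compound 4

The source may report more compounds than this note shows. Statements on the series, on what has been measured and on what is new or still open speak of the compounds shown alone.

Measured compounds in a functional assay on MDA-MB-231 cells (Homo sapiens) for antiproliferative activity, read by MTT assay, with a stated time of 72 h; on this read-out lower numbers stand for stronger inhibition and higher numbers for weaker inhibition:
Compound 1 `CC1=CC[C@H]2[C@H](CC[C@]2(C)O)C(C)(C)[C@@H]1CC[C@H]1[C@]2(C)CC[C@H](OC(=O)c3ccncc3)C(C)(C)O[C@H]2CC[C@@]1(C)O` gives 18000 nM
Compound 2 `CC1=CC[C@H]2[C@H](CC[C@]2(C)O)C(C)(C)[C@@H]1CC[C@H]1[C@]2(C)CC[C@H](OC(=O)NCc3ccccc3)C(C)(C)O[C@H]2CC[C@@]1(C)O` gives 40300 nM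
Compound 3 `CC1=CC[C@H]2[C@H](CC[C@]2(C)O)C(C)(C)[C@@H]1CC[C@H]1[C@]2(C)CC/C(=N/O)C(C)(C)O[C@H]2CC[C@@]1(C)O` gives 42700 nM

Compound 3 and compound 2 match within the usual scatter, while compound 1 shows the lower number of the three. Compound 4 `CC1=CC[C@H]2[C@H](CC[C@]2(C)O)C(C)(C)[C@@H]1CC[C@H]1[C@]2(C)CC/C(=N/OCc3ccccc3)C(C)(C)O[C@H]2CC[C@@]1(C)O` differs from compound 3 by one change, benzyl in place of hydrogen on an oxygen. Among the compounds with values here, no measured step makes this exchange. Within the data shown here, the only step available, a 2.2-fold higher number from compound 1 to compound 2 (0.35 log units; beyond the scatter) (benzylamino in place of pyridin-4-yl on a carbonyl carbon), is modest and lies elsewhere, so it offers weak guidance. No shift beyond the scatter is therefore expected in this assay. The estimate implies an expected 1.1-fold lower number from compound 3 to compound 4 (0.05 log units; within the scatter). For compound 4 the estimated value is 38000 nM (expected range 15000 nM to 80000 nM).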

Compound 4, half-maximal inhibitory concentration: 38200 nM
Estimate against measurement, compound 4: 1.0-fold (0.00 log units) below, and the stated range covers the measured number.
By their numbers in this assay, from the lowest: compound 1; then compounds 4, 2 and 3 (each within the scatter of the next).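

In this assay, benzyloxy replaces hydroxy on an oxygen whose other neighbour is a double-bonded nitrogen, and the outcome is a 1.1-fold lower number from compound 3 to compound 4 (0.05 log units; within the scatter) at this position. Adding the benzyl group and its aromatic ring here therefore does not move the number beyond the scatter, so this exchange leaves the antiproliferative read-out effectively unchanged. Nothing available explains this result. 

The compounds shown leave open whether a methyl group or a longer alkyl chain on this oxygen would behave the same way. They also leave open what a chain ending in an amine or a carboxylic acid would do there.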